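The source may report more compounds than this note shows. Statements on the series, on what has been measured and on what is new or still open speak of the compounds shown alone.

Measured in a functional assay on cells for antagonist activity at Free fatty acid receptor 1 (Homo sapiens), read by TR-FRET and inositol phosphate accumulation, with a stated time of 2 h; on this read-out higher numbers stand for weaker inhibition and lower numbers for stronger inhibition:

compound 1, `Cc1cc(COc2ccccc2F)nc(-c2ccccn2)n1`: 398 nM
compound 2, `Cc1cc(COc2ccc(F)cc2F)nc(-c2ccccn2)n1`: 398 nM
compound 3, `Cc1cc(COc2ccc(F)c(F)c2)nc(-c2ccccn2)n1`: 501 nM

Compound 2 differs from compound 1 by fluoro in place of hydrogen on an aromatic carbon, and this gave no change at the digits printed from compound 1 to compound 2 (within the scatter). Compound 3 and compound 1 share the core but differ in a way that is not broken down here; their two values lie within the scatter of each other, so no order can be read from them.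

Compound 4, `Cc1cc(COc2cc(F)c(F)c(F)c2)nc(-c2ccccn2)n1`, is not yet measured. It differs from compound 3 by fluoro in place of hydrogen on an aromatic carbon. This is the same kind of change as that from compound 1 to compound 2, but the surroundings are not the same: here the entering fluoro is ortho to a fluoro group, meta to a fluoro group and meta to a large group, whereas in compound 2 it is meta to a fluoro group and para to a large group.

In this assay, among the compounds with values here, the step from compound 3 to compound 4 is expected to be a 1.0-fold lower number from compound 3 to compound 4 (0.00 log units; within the scatter), resting on the flat step no change at the digits printed from compound 1 to compound 2 (within the scatter) seen for the same kind of change; the single precedent limits confidence. Compound 4 is accordingly estimated at 500 nM, with a likely range from 250 nM to 1000 nM.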

Compound 4, half-maximal inhibitory concentration: 398 nM
The estimate for compound 4 lay 1.3-fold (0.10 log units) above the measured number; the range from low to high includes it.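

In this assay, the fluoro in place of hydrogen on an aromatic carbon gave a 1.3-fold lower number from compound 3 to compound 4 (0.10 log units; within the scatter), and it can now be set beside the earlier case: the same change on two cores in this assay, no change at the digits printed (within the scatter) from compound 1 to compound 2 and a 1.3-fold lower number (0.10 log units; within the scatter) from compound 3 to compound 4, 1.3-fold (0.10 log units) apart, within the scatter of two such steps

The change therefore carried from one core to the other as a flat step, even though the surroundings differ; in compound 4 the fluoro enters ortho to a fluoro group, meta to a fluoro group and meta to a large group. Within the data shown here, this rests on only two pairs, and it does not show that the step would stay flat on another core or at another place on the ring.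

Among the compounds shown, every group varied on this ring is fluoro, so it remains open whether a chloro, methoxy or trifluoromethyl group there would move the number beyond the scatter. The methyl group on the shared core is also constant, leaving open what an amine or a carboxylic acid in its place would do.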